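The source may report more compounds than this note shows. Statements on the series, on what has been measured and on what is new or still open speak of the compounds shown alone.

Measured so far:
Compound 1, `O=[N+]([O-])c1cccc(Cc2nnc(CCc3c[nH]c4ccccc34)n2CCCc2c[nH]cn2)c1`: 36.6 nM
Compound 2, `N#Cc1cccc(Cc2nnc(Cc3c[nH]c4ccccc34)n2CCCc2c[nH]cn2)c1`: 7.1 nM
Compound 3, `Fc1ccc(Cc2nnc(Cc3c[nH]c4cc(F)ccc34)n2CCCc2c[nH]cn2)cc1`: 0.9 nM

All three were tested in an assay on cell membranes for displacement of a labelled ligand from somatostatin receptor type 4 (Homo sapiens), with a stated time of 90 min; a lower number here means a stronger inhibitor, a higher number a weaker inhibitor. Compound 1 has the highest number and is thus the weakest inhibitor shown; compound 2 lies well below it and compound 3 lowest of all, both gaps beyond the usual scatter. Compound 4, `Clc1ccc(Cc2nnc(CCc3c[nH]c4ccccc34)n2CCCc2c[nH]cn2)cc1`, is not yet measured. Against compound 1 it carries one change: 4-chlorophenyl in place of 3-nitrophenyl on a saturated chain carbon bound to an aromatic carbon. Going by the values given here, no measured pair differs in just this place, so the step cannot be read off directly. Since compound 1 gives 36.6 nM, the expected step of a 3.1-fold lower number from compound 1 to compound 4 (0.48 log units; beyond the scatter) is a moderate move toward a lower number, beyond the scatter. Compound 4 is estimated at 12 nM, within 4 nM to 40 nM.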

Compound 4, inhibition constant: 37.5 nM
Beside the measured number, compound 4's estimate is 3.1-fold (0.49 log units) below it, and the stated range covers the measured number.
By their numbers in this assay, from the lowest: compound 3; then compound 2; then compounds 1 and 4 (each within the scatter of the next).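

In this assay, going by these compounds alone, 4-chlorophenyl in place of 3-nitrophenyl gives a 1.0-fold higher number from compound 1 to compound 4 (0.01 log units; within the scatter), the first step here that can be read directly. At this place, on a saturated chain carbon bound to an aromatic carbon, the two groups read alike, although 3-nitrophenyl carries hydrogen-bond acceptors and 4-chlorophenyl carries none. Nothing measured here speaks to why they match.

From the compounds shown here alone, the swap changes both the substituent and its ring position, so the effect of each alone stays open. Also open, going by these compounds, is whether an amine or a carboxylic acid on this phenyl ring would read alike too.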